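Enantiomer of compound 2 in the EZH2 cell assay

The compounds below may be only part of what the source reports. "The series", "measured", "known", "first", "only" and "open" are said of these compounds alone.

Measured so far:
compound 1, `COC(c1cc(Cl)c2c(c1Cl)C(=O)N(Cc1c(C)cc(C)[nH]c1=O)CC2)C1CCS(=O)(=O)CC1`, 430 nM; 18 nM (2 entries)
compound 2, `Cc1cc(C)c(CN2CCc3c(Cl)cc([C@H](CO)[C@@H]4CCCO4)c(Cl)c3C2=O)c(=O)[nH]1`, 41 nM
compound 3, `Cc1cc(C)c(CN2CCc3c(Cl)cc(C(CO)C4CCOC4)c(Cl)c3C2=O)c(=O)[nH]1`, 1010 nM; 15 nM (2 entries)

Going by the values given here, in an assay on cells for inhibition of histone-lysine N-methyltransferase EZH2 (Homo sapiens), read by ELISA, with a stated time of 72 h (a lower number here means a stronger inhibitor, a higher number a weaker inhibitor), compound 2 gives 41 nM, the only number recorded for it; two further entries give no single number. Among the compounds with values here, no pair of measured compounds differs in one place, so no measured step is available to lean on. Compound 1 shows the several entries of compound 1 in this assay, 430 nM; 18 nM (2 entries) and compound 3 shows (the several entries of compound 3 in this assay, 1010 nM; 15 nM (2 entries)), each spanning a wide range within its own entries.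

Compound 4, `Cc1cc(C)c(CN2CCc3c(Cl)cc([C@@H](CO)[C@H]4CCCO4)c(Cl)c3C2=O)c(=O)[nH]1`, is the mirror image of compound 2: the two compounds have the same atoms and bonds and differ only in configuration as drawn: 2 of 2 stereo elements differ (all stereocentres are inverted: mirror images); a stereocentre at a saturated chain carbon is drawn R in compound 2 and S in compound 4; a stereocentre at a saturated ring carbon is drawn S in compound 2 and R in compound 4. Within the data shown here, nothing among the measured compounds indicates how the two mirror images compare, but a change of this kind is commonly beyond the scatter, and the direction cannot be read from the data. Taking compound 2 as the more potent image, compound 4 is expected to be weaker, with the step of a 7.3-fold higher number from compound 2 to compound 4 (0.86 log units; beyond the scatter) as the estimate. Compound 4 is estimated at 300 nM, in the range 30 nM to 3000 nM.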

Compound 4, half-maximal inhibitory concentration: 1020 nM
Compound 4: the middle estimate sits 3.4-fold (0.53 log units) below what was measured, within the range that was stated.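

In this assay, the first readable step of the series is a 25-fold higher number from compound 2 to compound 4 (1.40 log units; beyond the scatter), so configuration alone separates this pair, with nothing leaving or entering: the fact that compounds 2 and 4 differ only in the configuration as drawn

Compound 1, drawn without configuration, has a similarly wide spread, which may reflect the same kind of difference, though nothing shown confirms this: the several entries of compound 1 in this assay, 430 nM; 18 nM (2 entries)

Compound 3, also drawn without configuration, raises the same possibility and carries the same caution: the several entries of compound 3 in this assay, 1010 nM; 15 nM (2 entries)

From the compounds shown here alone, whether the saturated chain carbon or the saturated ring carbon carries more of the step stays open, since both stereocentres invert together in this pair. Also open, going by these compounds, is how an amine or a carboxylic acid in place of the hydroxyl group would behave under either configuration.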